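Trifluoromethyl in place of methyl: working notes

The compounds below may be only part of what the source reports. "The series", "measured", "known", "first", "only" and "open" are said of these compounds alone.

In an ADME assay on cells (spleen, Mus musculus, strain C57BL/6) for inhibition, read by flow cytometry and propidium iodide staining, with a stated time of 24 h, at 37 degrees C (a lower number here means that less compound is needed, a higher number that more compound is needed for the effect), compound 1 `O=C(Cn1cc(CCCCO)nn1)NCc1ccccc1` gives 1700 uM and compound 3 `Cc1ccccc1-c1cn(CC(=O)NCc2ccccc2)nn1` gives 940 uM, two numbers within the scatter of each other. Compound 2 `O=C(Cn1cc(C(=O)O)nn1)NCc1ccccc1` is reported as "non-toxic" (no number reported), with no number given. Compound 4 `O=C(Cn1cc(-c2ccccc2C(F)(F)F)nn1)NCc1ccccc1` differs from compound 3 by trifluoromethyl in place of methyl on an aromatic carbon. Within the data shown here, the only measured step, a 1.8-fold lower number from compound 1 to compound 3 (0.26 log units; within the scatter), lies within the scatter and concerns a different change, 2-methylphenyl in place of 4-hydroxybutyl. No measurement covers the present exchange, so no shift beyond the scatter is expected in this assay. The expected step, a 1.2-fold lower number from compound 3 to compound 4 (0.07 log units; within the scatter), stays within the scatter. Compound 4 is estimated at 800 uM, with an expected range of 350 uM to 1800 uM.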

Compound 4, concentration for half-maximal effect: "non-toxic" (no number reported)
Compound 4: no number reported; no gap can be computed for the estimate.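

Among these compounds, compound 4 is reported as "non-toxic" with no number, and no step from compound 3 to compound 4 can be read in this assay. No evidence bears on this result. The compounds shown leave open what size of shift, if any, trifluoromethyl in place of methyl produces.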